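The compounds below may be only part of what the source reports. "The series", "measured", "known", "first", "only" and "open" are said of these compounds alone.

Working notes on the series.

Compound 3 `Cc1ccc(C2=Nn3c(nnc3C(C)c3ccc(-c4ccccc4)c(F)c3)SC2)cc1` carries a methyl on the phenyl attached to the shared core, and in a functional assay on MCF7 cells (Homo sapiens) for inhibition, read by sulforhodamine B assay, with a stated time of 72 h (a higher number here means a weaker inhibitor, a lower number a stronger inhibitor), compound 3 gives 5000 nM. Compound 1 `CC(c1ccc(-c2ccccc2)c(F)c1)c1nnc2n1N=C(c1ccc(OC(F)(F)F)cc1)CS2` carries a trifluoromethoxy at the same position and in this assay compound 1 gives 4800 nM. Compound 2 `CC(c1ccc(-c2ccccc2)c(F)c1)c1nnc2n1N=C(c1ccccc1)CS2` carries hydrogen there, and in this assay compound 2 gives 7400 nM. Compound 3 thus sits within the scatter of both other members: a 1.0-fold higher number from compound 1 to compound 3 (0.02 log units; within the scatter), a 1.5-fold lower number from compound 2 to compound 3 (0.17 log units; within the scatter), and a 1.5-fold higher number from compound 1 to compound 2 (0.19 log units; within the scatter). Every change tried so far at this aromatic carbon has left the number unmoved beyond the scatter.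

Compound 4 `CC(c1ccc(-c2ccccc2)c(F)c1)c1nnc2n1N=C(c1ccc([N+](=O)[O-])cc1)CS2` differs from compound 3 as follows: nitro in place of methyl on an aromatic carbon. For the measured compounds named here, no measured pair shows a nitro at this position, so the expectation rests only on the three steps above, all within the scatter. Compound 4 is therefore expected to stay close to compound 3, with an estimated step of no change at the digits printed from compound 3 to compound 4 (within the scatter). Compound 4 is estimated at 5000 nM, with a range of 2500 nM to 10000 nM.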

Compound 4, half-maximal inhibitory concentration: 7800 nM
Beside the measured number, compound 4's estimate is 1.6-fold (0.19 log units) below it; the measured number falls inside the stated range.
By their numbers in this assay, from the lowest: compounds 1, 3, 2 and 4 (each within the scatter of the next).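

In this assay, nitro behaves like the other groups at this aromatic carbon, with every new step within the scatter (a 1.6-fold higher number from compound 3 to compound 4 (0.19 log units; within the scatter)), (a 1.1-fold higher number from compound 2 to compound 4 (0.02 log units; within the scatter)) and (a 1.6-fold higher number from compound 1 to compound 4 (0.21 log units; within the scatter)). Even the swap of methyl for nitro, which adds heavy atoms and hydrogen-bond acceptors, does not separate compound 4 from the rest, so hydrogen, methyl, trifluoromethoxy and nitro at this place cannot be told apart in this series. Nothing available speaks to what lies behind this flat result.

On these data alone, whether the same holds for an amine, a carboxylic acid or a longer chain at this aromatic carbon stays open. As far as these compounds go, all four compounds keep the rest of the structure fixed, so the effect of a change elsewhere on the shared core also stays open.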